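A few compounds are considered here, and "the series" means these few. Any claim that something is new, unique, unknown or untested is made for them only; others in the source may bear on it.

Compound 1 `C#Cc1cn([C@@H]2O[C@H](CO)[C@@H](O)[C@H]2O)c2ncnc(OC)c12` is a nucleoside carrying an ethynyl group and a methoxy group on its fused core. In a functional assay on HCT-116 cells (Homo sapiens), read by MTT assay, with a stated time of 72 h (a higher number here means a weaker inhibitor, a lower number a stronger inhibitor), compound 1 gives 4060 nM, the highest of the two numbers measured. Compound 3 `C#Cc1cn([C@@H]2O[C@H](CO)[C@@H](O)[C@H]2O)c2ncnc(N(C)C)c12` differs from it only in having dimethylamino in place of methoxy on an aromatic carbon, and in this assay compound 3 gives 180 nM; the step is a 23-fold lower number from compound 1 to compound 3 (1.35 log units; beyond the scatter). Compound 2 `Nc1nc2c(c(-c3ccccc3)cn2[C@@H]2O[C@H](CO)[C@@H](O)[C@H]2O)c(=O)[nH]1` has a different core and a phenyl group, and in this assay compound 2 gives > 20000 nM, which is a limit of the assay and not a number.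

Compound 4 `COc1ncnc2c1c(-c1ccsc1)cn2[C@@H]1O[C@H](CO)[C@@H](O)[C@H]1O` keeps the methoxy group of compound 1 and changes the other substituent: thiophen-3-yl in place of ethynyl on an aromatic carbon. Within the data shown here, no measured step touches this position, so the single measured step, from compound 1 to compound 3, concerns a different site and bears on the change only by showing that the core tolerates large swings in this assay. Among the measured compounds shown here, compound 2, the only compound with an aromatic ring at the corresponding place, sits at a limit but on another core. Compound 4 is therefore expected to stay near compound 1, with a 1.5-fold higher number from compound 1 to compound 4 (0.17 log units; within the scatter) within the scatter, and its estimated value in this assay is 6000 nM (between 1500 nM and 25000 nM).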

Compound 4, half-maximal inhibitory concentration: 120 nM
Estimate against measurement, compound 4: 50-fold (1.70 log units) above; measured number below the stated range.
By their numbers in this assay, from the lowest: compounds 4 and 3 (each within the scatter of the next); then compound 1. At a limit, above all of these: compound 2.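

In this assay, replacing ethynyl with thiophen-3-yl gives a 34-fold lower number from compound 1 to compound 4 (1.53 log units; beyond the scatter), so this aromatic carbon of the five-membered ring, and not only the site of the methoxy group, can move the number strongly. With the methoxy group kept, the ethynyl group is not needed for a low number on this core, since a five-membered aromatic ring with 5 heavy atoms can stand in its place. Compound 2, the only other compound shown with an aromatic ring at this place, has a different core, and its value is a limit of the assay and not a number: the limit of > 20000 nM in this assay, at which 1 of the 4 values shown sits.

The compounds shown leave open whether the step belongs to thiophen-3-yl in particular or would also follow from a phenyl ring, a furan-3-yl ring or a longer alkyne chain on the core of compound 1. They also leave open whether thiophen-3-yl gives a similar step when paired with the dimethylamino group of compound 3, and they give no account of what lies behind the step.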